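Aryl changes on the ring amine nitrogen: toward compound 4

The source may report more compounds than this note shows. Statements on the series, on what has been measured and on what is new or still open speak of the compounds shown alone.

Measured so far:
- compound 1, `Nc1scc(CN2CCN(c3cccc(Cl)c3Cl)CC2)c1C(=O)c1ccc(Cl)cc1`: compound 1 gives 1% in a functional assay on CHO cells with adenosine receptor A1 (Homo sapiens) as the target, read by cAMP accumulation and immunoassay, with a stated time of 6 min, tested at 0.01 uM; on this read-out higher numbers stand for a weaker effect at the one concentration tested and lower numbers for a stronger effect
- compound 2, `Nc1scc(CN2CCN(c3ccc(F)cc3Cl)CC2)c1C(=O)c1ccc(Cl)cc1`: compound 2 gives 6.1% in this assay
- compound 3, `Nc1scc(CN2CCN(c3ccccc3F)CC2)c1C(=O)c1ccc(Cl)cc1`: compound 3 gives 2.1% in this assay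

Compound 3 stands second highest of the three numbers. Its nearest neighbour is compound 1, with a number 1.1 percentage points higher from compound 1 to compound 3 (within the scatter); its furthest is compound 2, with a number 4 percentage points lower from compound 2 to compound 3 (within the scatter). Both gaps sit within the scatter, so the three measured compounds are not separated by these data.

Compound 4, `Nc1scc(CN2CCN(c3c(F)cc(F)cc3F)CC2)c1C(=O)c1ccc(Cl)cc1`, differs from compound 3 in one place: 2,4,6-trifluorophenyl in place of 2-fluorophenyl on an amine nitrogen in a ring.

The measured steps that bear on this change are those exchanging the aryl group on the same amine nitrogen in the ring: a number 5.1 percentage points higher from compound 1 to compound 2 (within the scatter), a number 1.1 percentage points higher from compound 1 to compound 3 (within the scatter) and a number 4 percentage points lower from compound 2 to compound 3 (within the scatter). Each of these lies within the scatter. Compound 4 is therefore expected to show no step beyond the scatter in this assay, with the value remaining in the low range of the series; the expected step is a number 0.9 percentage points higher from compound 3 to compound 4 (within the scatter). Compound 4 is estimated at 3%, with a range from 0% to 12%.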

Compound 4, a percentage reported as activity, at one concentration (the size of the read-out at that concentration, not a potency): 4.2%
For compound 4 the middle estimate is 1.2 percentage points below the measured one, and the stated range covers the measured number.
By their numbers in this assay, from the lowest: compounds 1, 3, 4 and 2 (each within the scatter of the next).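

In this assay, 2,4,6-trifluorophenyl on the amine nitrogen in the ring gives a number 2.1 percentage points higher from compound 3 to compound 4 (within the scatter); against the two chlorine-bearing aryl groups, the readings are a number 1.9 percentage points lower from compound 2 to compound 4 (within the scatter) and a number 3.2 percentage points higher from compound 1 to compound 4 (within the scatter). The position therefore now holds four different halogen-bearing phenyl groups, including the 2,4,6-trifluorophenyl group, with no step beyond the scatter among the steps printed for this series. No measurement on hand offers an explanation for this flat result.

All four compounds carry a halogen-bearing phenyl on this nitrogen and are compared at a single concentration, so the limit of what this position tolerates remains undefined. Whether an unsubstituted phenyl, or a phenyl bearing a methoxy group or a carboxylic acid, would stay within the scatter of these compounds remains open.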